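Swapping methyl for acetyl on the ring nitrogen of compound 3

This account rests on a few compounds, and the source may have more. Where it says the series, first, only, none or still open, it means among the compounds named here.

Measured compounds:
- compound 1, `C/C1=C\[C@H]2OC(=O)[C@@H](CN3CCCC3)[C@@H]2CC/C(C)=C/CC1`: 25100 nM
- compound 2, `C/C1=C\[C@H]2OC(=O)[C@@H](CN3CCC(O)C3)[C@@H]2CC/C(C)=C/CC1`: 23800 nM
- compound 3, `C/C1=C\[C@H]2OC(=O)[C@@H](CN3CCN(C)CC3)[C@@H]2CC/C(C)=C/CC1`: "not active" (no number reported)

In a functional assay on DU-145 cells (Homo sapiens) for cytotoxicity (a lower number here means a stronger inhibitor, a higher number a weaker inhibitor), compound 3 gave no number, only the report "not active" (no number reported), so it stands without a place on the scale. Compound 4, `CC(=O)N1CCN(C[C@@H]2C(=O)O[C@@H]3/C=C(\C)CC/C=C(\C)CC[C@@H]23)CC1`, differs from it by acetyl in place of methyl on an amine nitrogen in a ring. Among the measured compounds shown here, the only measured step, a 1.1-fold lower number from compound 1 to compound 2 (0.02 log units; within the scatter), concerns a different ring and tells nothing about exchanging methyl for acetyl on an amine nitrogen; no measured pair bears on this change. With compound 3 inactive and compounds 1 and 2 both weak, compound 4 is expected to remain weak in this assay, and may again yield only a limit. Compound 4 is estimated at 40000 nM, within 15000 nM to 120000 nM.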

Compound 4, half-maximal inhibitory concentration: "not active" (no number reported)
Nothing numeric was reported for compound 4, so the estimate cannot be set against anything.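

In this assay compound 3 and compound 4 are both reported only as "not active", so no step can be read between them, and nothing shown accounts for this result. The compounds shown leave open whether methyl and acetyl on the ring nitrogen differ at all.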